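Shifting a fluorine around the aniline ring

The compounds below may be only part of what the source reports. "The series", "measured", "known", "first", "only" and "open" are said of these compounds alone.

Compound 2 `Cc1n[nH]c2ccc(-c3nc4cnc(N5CCN(C)CC5)cn4c3Nc3cccc(F)c3)cc12` carries a 3-fluorophenyl group on a ring nitrogen of the shared core. Among the measured compounds shown here, in a functional assay on MV4-11 cells (Homo sapiens) for inhibition, with a stated time of 120 h, tested at 10 uM (a lower number here means less inhibition, a higher number more inhibition at the concentration tested (going by the name of the read-out)), compound 2 gives 18.5%, which is the higher of the two numbers measured so far. Its nearest neighbour is compound 1 `Cc1n[nH]c2ccc(-c3nc4cnc(N5CCN(C)CC5)cn4c3Nc3ccccc3F)cc12`, which in this assay gives 0%. For the measured compounds named here, the only measured step, a number 18.5 percentage points higher from compound 1 to compound 2 (beyond the scatter), shows that moving the single fluorine from one position of the phenyl ring to another can shift the read-out by a modest amount beyond the scatter.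

Compound 3 `Cc1n[nH]c2ccc(-c3nc4cnc(N5CCN(C)CC5)cn4c3Nc3ccc(F)cc3)cc12` differs from compound 2 in 4-fluorophenyl in place of 3-fluorophenyl on a nitrogen on an aromatic ring. Going by the values given here, this again moves the fluorine to a new position on the phenyl ring, and the one measured step does bear on it, though a different pair of positions is involved, so its direction cannot be read off directly. The step of a number 3.5 percentage points higher from compound 2 to compound 3 (within the scatter) is expected to be small, with the number staying near that of compound 2 and possibly a little higher. The estimate for compound 3 in this assay is 22%, within a range from 0% to 50%.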

Compound 3, a percentage reported as inhibition, at one concentration (the size of the read-out at that concentration, not a potency): 0%
The estimate for compound 3 lay 22 percentage points above the measured number; low and high end bracket the measured number.
By their numbers in this assay, from the lowest: compounds 1 and 3 (each within the scatter of the next); then compound 2.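

The change from 3-fluorophenyl to 4-fluorophenyl on this nitrogen is not neutral in this assay, as the result is a number 18.5 percentage points lower from compound 2 to compound 3 (beyond the scatter). The 2-fluorophenyl and 4-fluorophenyl groups cannot be told apart here, with no change at the digits printed from compound 1 to compound 3 (within the scatter), so among these three fluorine placements only the 3-fluorophenyl group of compound 2 stands apart from the other two. Nothing available explains why the read-out should differ for one placement of the fluorine and not for the others.

Compound 2 gives only 18.5% at a single concentration, so how these compounds would behave across a range of concentrations remains an open question. From the compounds shown here alone, it also remains open whether the difference belongs to fluorine in particular or to the placement of any group on this ring, which a comparison of compound 2 with an unsubstituted phenyl, a 3-chlorophenyl or a 3-methoxyphenyl group on the same nitrogen could begin to address.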